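A few compounds are considered here, and "the series" means these few. Any claim that something is new, unique, unknown or untested is made for them only; others in the source may bear on it.

Compound 1, with the structure `CC(C)(C)c1cc(NC(=O)Nc2ccc(-c3cn4ccccc4n3)cc2)no1`, is examined in a functional assay on MV4-11 cells (Homo sapiens) for cytotoxicity, read by MTT assay, with a stated time of 72 h (on this read-out higher numbers stand for weaker inhibition and lower numbers for stronger inhibition), where compound 1 gives 3.09 nM. Among the three compounds measured this is the second highest number. The closest neighbour is compound 3, `Cc1ccn2cc(-c3ccc(NC(=O)Nc4cc(C(C)(C)C)on4)cc3)nc2c1`, which gives 0.79 nM; the most distant is compound 2, `CC(C)(C)c1cc(NC(=O)Nc2ccc(-c3nc4ccccc4s3)cc2)no1`, which gives 172 nM. The step of a 56-fold higher number from compound 1 to compound 2 (1.75 log units; beyond the scatter) swaps one of the two fused rings attached to the shared core for another, and the step of a 3.9-fold lower number from compound 1 to compound 3 (0.59 log units; beyond the scatter) adds a methyl in place of hydrogen on the core.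

Compound 4, `Cc1ccc2nc(-c3ccc(NC(=O)Nc4cc(C(C)(C)C)on4)cc3)cn2c1`, differs from compound 1 by methyl in place of hydrogen on an aromatic carbon. Within the data shown here, of the measured steps only the one from compound 1 to compound 3 bears on this change, since it too places a single methyl on the fused ring of the shared core, and it lowered the number by a modest amount. The ring swap in compound 2 is of a different kind and says nothing about a methyl. A methyl on the same ring, though at a different carbon, is therefore expected to give a modest lowering in this assay rather than a large one, though the exact size for compound 4 remains to be seen.

Compound 4 is therefore expected to give 1.5 nM, with a likely range from 0.6 nM to 4 nM, corresponding to an estimated step of a 2.1-fold lower number from compound 1 to compound 4 (0.31 log units; beyond the scatter).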

Compound 4, half-maximal inhibitory concentration: 4.08 nM
The estimate for compound 4 lay 2.7-fold (0.43 log units) below the measured number; measured number outside the range, above it.
By their numbers in this assay, from the lowest: compound 3; then compounds 1 and 4 (each within the scatter of the next); then compound 2.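

In this assay, a methyl on this carbon of the six-membered aromatic ring, two atoms from the ring nitrogen, gives a 1.3-fold higher number from compound 1 to compound 4 (0.12 log units; within the scatter), so at this position the added carbon makes no difference that can be told from the scatter. The earlier compounds shown here showed only that a methyl on this ring can lower the number, with a 3.9-fold lower number from compound 1 to compound 3 (0.59 log units; beyond the scatter), and the new result shows that this lowering does not come with every carbon of the ring: the same methyl at another carbon gives compound 3 at 0.79 nM and compound 4 at 4.08 nM, so the place of the group counts as well as its presence. No measurement shown here accounts for this dependence on position.

The compounds shown leave open whether a larger or different group on this same carbon, such as an ethyl, a methoxy, a chlorine or an amine, would also leave the number within the scatter or would move it in either direction. They also leave open what a methyl would do at the remaining carbons of this ring.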